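Imidazole substituent change in a biphenyl acid series

This account rests on a few compounds, and the source may have more. Where it says the series, first, only, none or still open, it means among the compounds named here.

Working notes on a small set of biphenyl carboxylic acids tested in an in vitro functional assay on cells for agonist activity at Bombesin receptor subtype-3 (Homo sapiens), read by luminescence and calcium flux; on this read-out lower numbers stand for an effect already at smaller amounts and higher numbers for an effect only at larger amounts of compound. Compound 1 `CCCCc1cnc(Cc2ccc(-c3ccccc3C(=O)O)cc2)[nH]1` reports only a limit in this assay, > 10000 nM, and nothing beyond the limit itself is known of it (the limit of > 10000 nM in this assay, at which 1 of the 3 values shown sits). Compound 2 `CCCCc1cnc(C(C)Cc2ccc(-c3ccccc3C(=O)O)cc2)[nH]1` gives 2760 nM in this assay. Compound 3 `O=C(O)c1ccccc1-c1ccc(CCc2ncc(Cc3ccccc3F)[nH]2)cc1` gives 177 nM in this assay, the lowest of the two numbers available; the nearest, compound 2, sits at a higher number, and that gap lies beyond the scatter. Going by the values given here, no two measured compounds differ in a single place, so no measured step exists within the set.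

Compound 4 `O=C(O)c1ccccc1-c1ccc(CCc2ncc(-c3ccccc3)[nH]2)cc1` has not been measured. Against compound 3 the change is phenyl in place of 2-fluorobenzyl on an aromatic carbon. Among the compounds with values here, no measured pair shows what this change does, so the expectation rests only on the general scale of the numbers seen. The step from compound 3 is expected to be a 3.4-fold higher number from compound 3 to compound 4 (0.53 log units; beyond the scatter), toward a higher number, of a size beyond the scatter but clearly smaller than the gap between compound 3 and compound 2. Compound 4 is therefore estimated at 600 nM in this assay, with a range from 150 nM to 3000 nM.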

Compound 4, half-maximal effective concentration: 4950 nM
Compound 4: the middle estimate sits 8.3-fold (0.92 log units) below what was measured, outside the stated range (above it).
By their numbers in this assay, from the lowest: compound 3; then compounds 2 and 4 (each within the scatter of the next). At a limit, above all of these: compound 1.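

In this assay, going by these compounds alone, phenyl in place of 2-fluorobenzyl on this aromatic carbon of the five-membered aromatic ring with 2 nitrogen gives a 28-fold higher number from compound 3 to compound 4 (1.45 log units; beyond the scatter) as the first single-place step. Within the data shown here, the number therefore depends strongly on the group at this position, at least in this pair, which the earlier compounds could not show because none of them differed in a single place. The change also removes the fluorine and the methylene link of the 2-fluorobenzyl group together, so this one step does not separate the part played by each.

Still open, as far as these compounds go, is whether plain benzyl on this carbon would give a number close to that of compound 3 or close to that of compound 4, and whether a longer link such as 2-phenylethyl or a different substituent such as an amine would be tolerated there. Nothing measured in these data bears on why the step is this large, so its size stands without an explanation.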